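Swapping the terminal aryl group on a diaryl urea

A few compounds are considered here, and "the series" means these few. Any claim that something is new, unique, unknown or untested is made for them only; others in the source may bear on it.

Compound 1 `O=C(Nc1ccc(Oc2ccc(-c3nccs3)cc2)cc1)Nc1cccc(C(F)(F)F)c1`: 64.1%
Compound 2 `O=C(Nc1ccc(Oc2ccc(-c3ncc[nH]3)cc2)cc1)Nc1cccc(C(F)(F)F)c1`: 28.1%

In a functional assay on MDA-MB-231 cells (Homo sapiens) for inhibition, read by MTT assay and WST assay, with a stated time of 72 h, tested at 10 uM (on this read-out lower numbers stand for less inhibition of growth and higher numbers for more inhibition of growth at the one concentration tested), compound 1 gives 64.1%, while compound 2 gives 28.1%, the lower of the two numbers. Going by the values given here, the one step measured so far, a number 36 percentage points lower from compound 1 to compound 2 (beyond the scatter), changes the ring at the far end of the shared core and says nothing about the urea end.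

Compound 3 `O=C(Nc1ccc(Oc2ccc(-c3ncc[nH]3)cc2)cc1)Nc1ccc(F)c(Cl)c1` differs from compound 2 only at that urea end: 3-chloro-4-fluorophenyl in place of 3-(trifluoromethyl)phenyl on an amide-type nitrogen. Among the compounds with values here, no measured pair shows what such a change does here, so the expectation can rest only on compound 2 itself. With nothing pointing up or down, the step of a number 0.1 percentage points lower from compound 2 to compound 3 (within the scatter) is expected to stay within the usual scatter. Compound 3 is therefore estimated at 28% in this assay, with a plausible range from 8% to 50%.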

Compound 3, percent growth inhibition at one concentration: 4.2%
For compound 3 the middle estimate is 23.8 percentage points above the measured one; the whole stated range lies above it.
By their numbers in this assay, from the lowest: compound 3; then compound 2; then compound 1.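

In this assay, the urea end proves to be a sensitive place: 3-chloro-4-fluorophenyl in place of 3-(trifluoromethyl)phenyl on an amide-type nitrogen gives a number 23.9 percentage points lower from compound 2 to compound 3 (beyond the scatter). Both ends of the molecule have now shown a measured effect on growth inhibition, the far ring through a number 36 percentage points lower from compound 1 to compound 2 (beyond the scatter) and the urea end through this swap. Both aryl groups are a single six-membered aromatic ring of carbon only, without hydrogen-bond donors or acceptors, so the difference lies in what that ring carries, and no measurement available here explains the fall.

On these data alone, whether the same swap would act alike with the 1,3-thiazol-2-yl ring of compound 1 stays open. So does the effect of an amine or a carboxylic acid on the aryl ring at the urea end.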